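Chalcone-pyrazole analogues: swapping the aminophenyl for difluorophenyl

The compounds below may be only part of what the source reports. "The series", "measured", "known", "first", "only" and "open" are said of these compounds alone.

Of the compounds shown here, three sharing one core have been measured in a functional assay on SNB-19 cells (Homo sapiens) for inhibition, read by sulforhodamine B assay, with a stated time of 48 h; a lower number here means a stronger inhibitor of growth, a higher number a weaker inhibitor of growth. Compound 1 `COc1cc(-c2cc(/C=C/C(=O)c3ccc(N)cc3)[nH]n2)cc(OC)c1OC` gives 9980 nM in this assay, the second highest of the three numbers. Compound 2 `COc1ccc(-c2cc(/C=C/C(=O)c3ccc(N)cc3)[nH]n2)cc1OC` gives 18000 nM, and the step of a 1.8-fold higher number from compound 1 to compound 2 (0.26 log units; within the scatter) lies within the scatter. Compound 3 `COc1cc(C(=O)/C=C/c2cc(-c3cc(OC)c(OC)c(OC)c3)n[nH]2)cc(OC)c1OC` gives 3690 nM, a lower number than compound 1 by a margin beyond the scatter.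

Compound 4 `COc1cc(-c2cc(/C=C/C(=O)c3ccc(F)c(F)c3)[nH]n2)cc(OC)c1OC` has not yet been measured. It differs from compound 1 in one place: 3,4-difluorophenyl in place of 4-aminophenyl on a carbonyl carbon. Within the data shown here, no measured step touches this place; the only step available, a 1.8-fold higher number from compound 1 to compound 2 (0.26 log units; within the scatter), concerns a methoxy on another ring and was within the scatter, so it offers no guide to the direction of the present change. With nothing in the data to push the number either way, compound 4 is expected to sit near compound 1, with the step of a 1.0-fold higher number from compound 1 to compound 4 (0.00 log units; within the scatter) estimated as no change beyond the scatter. Compound 4 is therefore estimated at 10000 nM in this assay, within a range from 3000 nM to 35000 nM.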

Compound 4, concentration for total growth inhibition: > 100000 nM
Compound 4: a limit, no number; the forecaster's own chance of this, stated with the estimate: 10%; middle value at least 10-fold (1.00 log units) away from the limit.
By their numbers in this assay, from the lowest: compound 3; then compounds 1 and 2 (each within the scatter of the next). At a limit, above all of these: compound 4.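

Among these compounds, the first step at this place is large: swapping 4-aminophenyl for 3,4-difluorophenyl on the carbonyl carbon gives an at least 10-fold higher number from compound 1 to compound 4 (1.00 log units; beyond the scatter). Compound 4 yields a limit, not a number, in this assay: the limit of > 100000 nM in this assay, at which 1 of the 4 values shown sits. So this place, which no earlier step touched, can move the number far beyond the scatter, whereas the methoxy step on the other ring stayed within it.

The change removes the amine and brings in two fluorines in a single step, and the compounds shown cannot say which of these carries the effect. Going by these compounds, what an unsubstituted phenyl, a hydroxyphenyl or an acetamidophenyl would give on the same carbonyl carbon remains open, as does whether a single fluorine behaves like the pair.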